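Series notes: cytotoxicity limits and the step to compound 4

The source may report more compounds than this note shows. Statements on the series, on what has been measured and on what is new or still open speak of the compounds shown alone.

Compound 1 `Nc1nc(NC2CC2)c2ncn(/C=C3/CC3(CO)CO)c2n1`, compound 2 `CC(C)CNc1nc(N)nc2c1ncn2/C=C1/CC1(CO)CO` and compound 3 `CCCCCCOc1nc(N)nc2c1ncn2/C=C1/CC1(CO)CO` share one core and differ only in the group on one aromatic carbon. In an ADME assay on HFF cells (Homo sapiens) for cytotoxicity, with a stated time of 8 days (on this read-out lower numbers stand for higher toxicity in this test and higher numbers for lower toxicity in this test), compound 1 gives > 300000 nM, which is a limit of the assay rather than a number. In this assay compound 2 gives > 300000 nM, again a limit. Compound 3 gives > 200000 nM in this assay, also a limit. Among the compounds with values here, because all three values sit at the limit of > 300000 nM in this assay, at which 2 of the 3 values shown sit, or (the limit of > 200000 nM in this assay, at which 1 of the 3 values shown sits), no step can be sized: a step that the two limits leave unreadable from compound 1 to compound 2, a step that the two limits leave unreadable from compound 1 to compound 3 and a step that the two limits leave unreadable from compound 2 to compound 3 are all unreadable. Compound 3 therefore stands at a limit, and the two other values are limits too.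

The change to compound 4 `CNc1nc(N)nc2c1ncn2/C=C1/CC1(CO)CO` is methylamino in place of hexyloxy on an aromatic carbon. Within the data shown here, no measured step bears on it with a readable size; every exchange of the group on this aromatic carbon so far left the cytotoxic concentration beyond the reach of this assay. The expected step is a step that the limit leaves unreadable from compound 3 to compound 4, nothing beyond the scatter, and most likely another limit. Compound 4 is estimated in this assay at 300000 nM, between 100000 nM and 1000000 nM.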

Compound 4, half-maximal cytotoxic concentration: 265000 nM
For compound 4 the middle estimate is 1.1-fold (0.05 log units) above the measured one; low and high end bracket the measured number.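

In this assay, within the data shown here, compound 4 gives the first value for this aromatic carbon that is a number and not a limit, so the methylamino group provides a readable reference point for the series. Against that reference there are two floors only: an at least 1.1-fold lower number from compound 2 to compound 4 (0.05 log units; that floor lies within the scatter), and an at least 1.1-fold lower number from compound 1 to compound 4 (0.05 log units; that floor lies within the scatter); neither shows a change beyond the scatter. The step from compound 3 cannot be read, and the true sizes of the other two steps stay unknown because compounds 1 and 2 stand at a limit: the limit of > 300000 nM in this assay, at which 2 of the 4 values shown sit.

Open, on these data alone, is whether an ethylamino or a morpholine group on this aromatic carbon would give a number or a limit in this assay. Also open, as far as these compounds go, is where such a number would fall relative to compound 4.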